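This account rests on a few compounds, and the source may have more. Where it says the series, first, only, none or still open, it means among the compounds named here.

Working notes on the series. All compounds share the same core: an aminophenyl ring on the exocyclic double bond and a substituted benzyl group on the ring nitrogen. Going by the values given here, compound 1 `Nc1ccc(/C=C2\SC(=O)N(Cc3ccc(C(F)(F)F)cc3)C2=O)cc1` gives 32000 nM in a functional assay on CCRF-CEM cells (Homo sapiens) for cytotoxicity, read by cell counting, with a stated time of 3 days (on this read-out higher numbers stand for weaker inhibition and lower numbers for stronger inhibition), and stands lowest of the two numbers so far; the nearest is compound 2 `Nc1ccc(/C=C2\SC(=O)N(Cc3ccc(Cl)cc3)C2=O)cc1`, which gives 87000 nM in this assay, a step of a 2.7-fold higher number from compound 1 to compound 2 (0.43 log units; beyond the scatter). Compound 3 `Cc1ccc(CN2C(=O)S/C(=C\c3ccc(N)cc3)C2=O)cc1` reaches only a limit of the assay, > 250000 nM, in this assay. The steps onward are an at least 2.8-fold higher number from compound 2 to compound 3 (0.45 log units; beyond the scatter) and an at least 7.8-fold higher number from compound 1 to compound 3 (0.89 log units; beyond the scatter); the limit in play is the limit of > 250000 nM in this assay, at which 1 of the 3 values shown sits.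

Compound 4 `Nc1cccc(/C=C2\SC(=O)N(Cc3ccc(C(F)(F)F)cc3)C2=O)c1` differs from compound 1 by 3-aminophenyl in place of 4-aminophenyl on a double-bonded chain carbon bound to a double-bonded ring carbon. None of the three measured steps alters the aminophenyl ring; each of them changes only the group on the benzyl ring. So no measured step gives a direct size for this change, and the expectation rests on compound 1 alone, with the move of the amino group taken as likely to stay within the scatter or, at most, to be modest, in either direction. For compound 4 the expected value in this assay is 45000 nM, with a range of 15000 nM to 160000 nM. That corresponds to an estimated step of a 1.4-fold higher number from compound 1 to compound 4 (0.15 log units; within the scatter).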

Compound 4, half-maximal inhibitory concentration: > 250000 nM
Compound 4: no number, only a limit; the forecaster's own chance of this, stated with the estimate: 15%; middle value at least 5.5-fold (0.74 log units) from the limit.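

Moving the amino group is the first change on this side of the shared core to be read, and in this assay it is not neutral: the step is an at least 7.8-fold higher number from compound 1 to compound 4 (0.89 log units; beyond the scatter). The groups that leave and enter have the same atoms and the same counts of donors and acceptors, so the read-out in this series depends on where the amino group sits, and not only on the group on the benzyl ring. Compound 4 gives only a limit and no number, so this step has a known floor but no known size, and the values of the series are now bunching at the top of the range: the limit of > 250000 nM in this assay, at which 2 of the 4 values shown sit.

On these data alone, whether 3-aminophenyl costs as much with chloro or methyl on the benzyl ring stays open, as compound 4 alone carries it, with trifluoromethyl. Also open, as far as these compounds go, is whether a hydroxyphenyl or a dimethylaminophenyl on a double-bonded chain carbon bound to a double-bonded ring carbon would hold the value of compound 1 or fall to the limit.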